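The source may report more compounds than this note shows. Statements on the series, on what has been measured and on what is new or still open speak of the compounds shown alone.

Measured compounds in a functional assay on Huh-7 cells (Homo sapiens) for inhibition, read by MTT assay, with a stated time of 48 h; on this read-out higher numbers stand for weaker inhibition and lower numbers for stronger inhibition:
compound 1 `COc1ccc2c(=O)c(/C=C/C(=O)Nc3ccccc3)coc2c1`, 9050 nM
compound 2 `Cc1ccccc1NC(=O)/C=C/c1coc2cc(O)ccc2c1=O`, 11100 nM
compound 3 `COc1ccc(CNC(=O)/C=C/c2coc3cc(O)ccc3c2=O)cc1`, 8430 nM

Compound 1 stands second highest of the three numbers. Its nearest neighbour is compound 3, whose number is lower by a difference within the scatter; the furthest is compound 2, whose number is higher, also within the scatter. Within the data shown here, the three measured numbers are therefore indistinguishable, and no pair of measured compounds differs in only one place, so no single-change step is available.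

Compound 4 `COc1ccc2c(=O)c(/C=C/C(=O)NCc3ccc(C)cc3)coc2c1` differs from compound 1 in one place: 4-methylbenzyl in place of phenyl on an amide-type nitrogen. Across the three measured compounds, the variation at the amide-type nitrogen and at the core goes with no change beyond the scatter, so the expectation for compound 4 in this assay is a step of no size beyond the scatter, in no firm direction, as in a 1.1-fold lower number from compound 1 to compound 4 (0.03 log units; within the scatter). The estimate for compound 4 in this assay is 8500 nM, with an expected range from 4200 nM to 17000 nM.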

Compound 4, half-maximal inhibitory concentration: 14300 nM
Compound 4: middle estimate off by 1.7-fold (0.23 log units), on the low side; the measured number falls inside the stated range.
By their numbers in this assay, from the lowest: compounds 3, 1, 2 and 4 (each within the scatter of the next).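

In this assay, among these compounds, the first single-place change, 4-methylbenzyl in place of phenyl on an amide-type nitrogen, gives a 1.6-fold higher number from compound 1 to compound 4 (0.20 log units; within the scatter) and so does not separate the two compounds. On the core of compound 1, this nitrogen therefore takes the group of 8 heavy atoms as well as the group of 6 heavy atoms without a step beyond the scatter, a reading that rests on this one pair alone. No available evidence bears on this step.

Open, on these data alone, is whether a carboxylic acid, an amine or a longer chain in place of 4-methylbenzyl on the amide-type nitrogen would give a step beyond the scatter. Also open is the effect of a change on the core itself, since no pair shown differs there and nowhere else.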